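The source may report more compounds than this note shows. Statements on the series, on what has been measured and on what is new or still open speak of the compounds shown alone.

Compound 3 `O=C(Nc1cc2c(Nc3ccc(F)c(Cl)c3)ncnc2cc1O[C@H]1CCOC1)N1CC(O)C1` stands second highest of the three numbers in a functional assay on A-431 cells (Homo sapiens) for antiproliferative activity, read by sulforhodamine B assay, with a stated time of 72 h; a higher number here means a weaker inhibitor, a lower number a stronger inhibitor: compound 3 gives 1930 nM, while compound 2 `CN(C)CCCNC(=O)Nc1cc2c(Nc3ccc(F)c(Cl)c3)ncnc2cc1O[C@H]1CCOC1` gives 226 nM and compound 1 `COC(CCNC(=O)Nc1cc2c(Nc3ccc(F)c(Cl)c3)ncnc2cc1O[C@H]1CCOC1)OC` gives 22000 nM. Compound 4 `O=C(Nc1cc2c(Nc3ccc(F)c(Cl)c3)ncnc2cc1O[C@H]1CCOC1)N1CCC(F)CC1` differs from compound 3 by 4-fluoropiperidin-1-yl in place of 3-hydroxyazetidin-1-yl on a carbonyl carbon. The measured steps at this carbonyl carbon were an 11-fold lower number from compound 1 to compound 3 (1.06 log units; beyond the scatter) and an 8.5-fold higher number from compound 2 to compound 3 (0.93 log units; beyond the scatter); both swapped open chains for the hydroxyazetidine, and none replaces one ring by another or removes the hydroxyl, so the bearing is indirect. Since the two neutral compounds 1 and 3 both sit well above compound 2, compound 4 is expected to land in the same weaker region, with a step of about a 2.1-fold higher number from compound 3 to compound 4 (0.32 log units; beyond the scatter). The estimate for compound 4 in this assay is 4000 nM, in the range 1000 nM to 20000 nM.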

Compound 4, half-maximal inhibitory concentration: 3040 nM
Compound 4: the middle estimate sits 1.3-fold (0.12 log units) above what was measured; measured number inside the range.
By their numbers in this assay, from the lowest: compound 2; then compounds 3 and 4 (each within the scatter of the next); then compound 1.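

In this assay, exchanging one ring for the other on the carbonyl carbon gives a 1.6-fold higher number from compound 3 to compound 4 (0.20 log units; within the scatter), so the two rings cannot be told apart here, although 4-fluoropiperidin-1-yl is larger than 3-hydroxyazetidin-1-yl and lacks its hydrogen-bond donor. Compound 4 stays clearly separated from both open chains, with a 13-fold higher number from compound 2 to compound 4 (1.13 log units; beyond the scatter) and a 7.2-fold lower number from compound 1 to compound 4 (0.86 log units; beyond the scatter). Nothing available explains these results. Going by these compounds, it remains open whether 4-(dimethylamino)piperidin-1-yl on this carbonyl carbon would approach the number of compound 2 (226 nM).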